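This account rests on a few compounds, and the source may have more. Where it says the series, first, only, none or still open, it means among the compounds named here.

Measured compounds:
compound 1, `N#CC1=C(N)Oc2c(c3nc4ccccc4nc3c3ccccc23)C12C(=O)N(Cc1cnnn1-c1ccc(Cl)cc1)c1ccccc12` — > 50000 nM
compound 2, `N#CC1=C(N)Oc2c(c3nc4ccccc4nc3c3ccccc23)C12C(=O)N(Cc1cnnn1-c1ccc(Br)cc1)c1ccccc12` — > 50000 nM
compound 3, `CCOc1ccc(-n2nncc2CN2C(=O)C3(C(C#N)=C(N)Oc4c3c3nc5ccccc5nc3c3ccccc43)c3ccccc32)cc1` — > 50000 nM

In an ADME assay on HUVEC cells (Homo sapiens) for antiproliferative activity, read by MTT assay, with a stated time of 48 h (a lower number here means a stronger inhibitor, a higher number a weaker inhibitor), compound 1 gives > 50000 nM, which is a limit of the assay and not a number. Compound 2 gives > 50000 nM in this assay, again a limit rather than a number. Compound 3 gives > 50000 nM in this assay, also a limit. Within the data shown here, the steps among them, a step that the two limits leave unreadable from compound 1 to compound 2, a step that the two limits leave unreadable from compound 1 to compound 3 and a step that the two limits leave unreadable from compound 2 to compound 3, therefore carry no readable size; the only thing the three values show is the limit of > 50000 nM in this assay, at which 3 of the 3 values shown sit.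

Compound 4, `N#CC1=C(N)Oc2c(c3nc4ccccc4nc3c3ccccc23)C12C(=O)N(Cc1cnnn1-c1ccc([N+](=O)[O-])cc1)c1ccccc12`, has not yet been measured in this assay. It differs from compound 1 in one place: nitro in place of chloro on an aromatic carbon. Among the measured compounds shown here, none of the measured steps changes the chloro to a nitro, so none bears directly on it; what they show is that swapping this one group for bromo or ethoxy left every compound at the limit.

On that footing compound 4 is expected to sit where compound 1 sits, with a step that the limit leaves unreadable from compound 1 to compound 4 that is expected to be unreadable, the value most likely coming back as a limit again. The estimate for compound 4 in this assay is 60000 nM, with a range from 20000 nM to 200000 nM.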

Compound 4, half-maximal inhibitory concentration: > 50000 nM
Compound 4 was reported as a limit (the forecaster's own chance of this, stated with the estimate: 80%); the middle value is on the limit's open side.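

In this assay compound 4 gives > 50000 nM, a limit of the assay and not a number, so its steps to compound 1, compound 2 and compound 3 cannot be read: the limit of > 50000 nM in this assay, at which 4 of the 4 values shown sit.

The compounds shown leave open how far past this limit any of the four lies, and whether any other group at this place would give a readable value.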